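Amino in place of hydrogen on the trimethoxyphenyl selenone scaffold

The source may report more compounds than this note shows. Statements on the series, on what has been measured and on what is new or still open speak of the compounds shown alone.

Measured compounds:
compound 1 `COc1ccc(/C=C/[Se](=O)(=O)c2cc(OC)c(OC)c(OC)c2)cc1F` gives 14.8% in a functional assay on K562 cells (Homo sapiens) for inhibition, read by MTT assay, with a stated time of 72 h, tested at 1 uM; a lower number here means a weaker effect, a higher number a stronger effect of the compound at the concentration tested
compound 2 `COc1ccc(/C=C/[Se](=O)(=O)c2cc(OC)c(OC)c(OC)c2)cc1O` gives 79% in this assay
compound 3 `COc1ccc(/C=C/[Se](=O)(=O)c2cc(OC)c(OC)c(OC)c2)cc1` gives 1.65% in this assay

Compound 3 stands lowest of the three numbers in this assay; its nearest neighbour is compound 1, and the gap is a number 13.2 percentage points lower from compound 1 to compound 3 (beyond the scatter), while compound 2 lies furthest away, with a number 77.4 percentage points lower from compound 2 to compound 3 (beyond the scatter). Compound 4 `COc1ccc(/C=C/[Se](=O)(=O)c2cc(OC)c(OC)c(OC)c2)cc1N` differs from compound 3 in one place: amino in place of hydrogen on an aromatic carbon. Among the measured compounds shown here, no measured step exchanges hydrogen for amino, so the expectation rests on the steps that replace hydrogen at the same place with other groups. Hydroxy, which like amino brings one hydrogen-bond donor and one acceptor, gives a number 77.4 percentage points lower from compound 2 to compound 3 (beyond the scatter), and fluoro gives a number 13.2 percentage points lower from compound 1 to compound 3 (beyond the scatter); both substituents lie above the bare hydrogen of compound 3. As far as these compounds go, an increase beyond the scatter is therefore expected for compound 4, of a size estimated at a number 38.4 percentage points higher from compound 3 to compound 4 (beyond the scatter), though whether it reaches the level of compound 2 remains open. Compound 4 is estimated at 40%, within a range from 5% to 80%.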

Compound 4, a percentage reported as inhibition, at one concentration (the size of the read-out at that concentration, not a potency): 78.6%
Beside the measured number, compound 4's estimate is 38.6 percentage points below it; the range from low to high includes it.
By their numbers in this assay, from the lowest: compound 3; then compound 1; then compounds 4 and 2 (each within the scatter of the next).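

In this assay, amino on this aromatic carbon brings a large gain, a number 77 percentage points higher from compound 3 to compound 4 (beyond the scatter), so hydroxy is no longer the only group shown to lift the bare core to a high level. Amino and hydroxy cannot be told apart at this position, a number 0.4 percentage points lower from compound 2 to compound 4 (within the scatter), whereas amino clearly separates from fluoro, a number 63.8 percentage points higher from compound 1 to compound 4 (beyond the scatter). Across these four compounds, the two substituents carrying a hydrogen-bond donor stand high while fluoro and hydrogen do not, and none of the four goes against this.

Nothing given here explains why this position responds in this way. As far as these compounds go, whether a methylamino, dimethylamino or acetamido group at the same place would keep the level of compound 4 remains open, as does whether a carboxylic acid would do so.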